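Removing the selenocyanate chain from compound 3

A few compounds are considered here, and "the series" means these few. Any claim that something is new, unique, unknown or untested is made for them only; others in the source may bear on it.

Compound 1, `COc1ccc(N(C)c2nc(C)nc3ccccc23)cc1OCCN`: 421 nM in a functional assay on LoVo cells (Homo sapiens) for inhibition, read by MTT assay, with a stated time of 48 h; a higher number here means a weaker inhibitor, a lower number a stronger inhibitor
Compound 2, `COc1ccc(N(C)c2nc(C)nc3ccccc23)cc1C(=O)OCCC[Se]C#N`: 854 nM
Compound 3, `COc1ccc(N(C)c2nc(C)nc3ccccc23)cc1OCCCCC[Se]C#N`: 5210 nM

Among these three, compound 3 gives the highest number, above compound 2 by a 6.1-fold higher number from compound 2 to compound 3 (0.79 log units; beyond the scatter) and above compound 1 by a 12-fold higher number from compound 1 to compound 3 (1.09 log units; beyond the scatter). Compound 4, `COc1ccc(N(C)c2nc(C)nc3ccccc23)cc1`, differs from compound 3 in one place: a hydrogen atom in place of a group of 9 heavy atoms (6 carbon, 1 nitrogen, 1 oxygen, 1 selenium; no ring), on an aromatic carbon. Going by the values given here, no measured step removes a group from this aromatic carbon outright. The nearest guides are the exchange that gave a 12-fold higher number from compound 1 to compound 3 (1.09 log units; beyond the scatter) and the one that gave a 2.0-fold higher number from compound 1 to compound 2 (0.31 log units; beyond the scatter), both showing that what sits on this carbon moves the number well beyond the scatter. A return toward the smaller compounds is therefore expected, as a 5.2-fold lower number from compound 3 to compound 4 (0.72 log units; beyond the scatter). The estimate for compound 4 in this assay is 1000 nM, with a range from 300 nM to 4000 nM.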

Compound 4, half-maximal inhibitory concentration: 8 nM
Compound 4: the middle estimate sits 130-fold (2.10 log units) above what was measured; the whole stated range lies above it.
By their numbers in this assay, from the lowest: compound 4; then compound 1; then compound 2; then compound 3.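

In this assay, hydrogen on this aromatic carbon gives a lower number than every chain shown, with a 650-fold lower number from compound 3 to compound 4 (2.81 log units; beyond the scatter), a 110-fold lower number from compound 2 to compound 4 (2.03 log units; beyond the scatter) and a 53-fold lower number from compound 1 to compound 4 (1.72 log units; beyond the scatter). The earlier compounds shown here only ranked these groups against one another; compound 4 shows that even the 2-aminoethoxy group, the smallest of them, stands far above the bare carbon. Nothing shown accounts for the size of these steps.

On these data alone, it remains open whether a single small group here, such as hydroxyl or fluorine, would keep the number near that of compound 4, and whether a primary amine on a shorter chain would recover any of the loss.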